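Side-chain variation on the amino-acid carbon

A few compounds are considered here, and "the series" means these few. Any claim that something is new, unique, unknown or untested is made for them only; others in the source may bear on it.

Compound 2 `O=C(O)C[C@H](NC(=O)CN(c1nc(Cl)nc2[nH]cnc12)C1CC1)C(=O)O` gives 38.9% in a functional assay on the whole organism (Tail, strain ICR) with Mus musculus as the target, in the tail flick test, with a stated time of 60 min, at a dose of 25 umol/kg by the oral route (on this read-out higher numbers stand for a stronger effect at the one dose given and lower numbers for a weaker effect), and compound 1 `CC[C@H](C)[C@H](NC(=O)CN(c1nc(Cl)nc2[nH]cnc12)C1CC1)C(=O)O` gives 36%; the two values lie within the scatter of each other, so compound 2 does not stand apart. Going by the values given here, the single measured step, a number 2.9 percentage points higher from compound 1 to compound 2 (within the scatter), bears directly on the next change, which alters the same side chain again. Compound 3 `CSCC[C@H](NC(=O)CN(c1nc(Cl)nc2[nH]cnc12)C1CC1)C(=O)O` carries (methylsulfanyl)methyl in place of carboxy on a saturated chain carbon, two bonds along the chain from an amide-type nitrogen and a carbonyl carbon. Because that earlier side-chain exchange produced a number 2.9 percentage points higher from compound 1 to compound 2 (within the scatter), no step beyond the scatter is expected for a number 1.9 percentage points lower from compound 2 to compound 3 (within the scatter) either. Compound 3 is therefore estimated at 37%, with a range from 22% to 52%.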

Compound 3, a percentage reported as activity, at one dose (the size of the read-out at that dose, not a potency): 22.8%
Compound 3: the middle estimate sits 14.2 percentage points above what was measured; the measured number falls inside the stated range.
By their numbers in this assay, from the lowest: compound 3; then compounds 1 and 2 (each within the scatter of the next).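

This side-chain position is not indifferent in this assay: the change gives a number 16.1 percentage points lower from compound 2 to compound 3 (beyond the scatter) and also a number 13.2 percentage points lower from compound 1 to compound 3 (beyond the scatter), whereas the earlier exchange stayed within the scatter. The 2-(methylsulfanyl)ethyl side chain therefore stands apart from both the carboxymethyl and sec-butyl side chains, which are not separated from each other. Nothing measured here accounts for this difference.

Open, as far as these compounds go, is how a side chain ending in an amine would compare at this carbon. From the compounds shown here alone, the effect of a longer chain carrying the sulfur also remains open.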